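The source may hold more compounds than are shown below. What is called first, only, known or untested is meant among the compounds shown, and "the series" means these compounds.

Compound 1 `Cc1nn(C)c(Oc2ccccc2Br)c1/C=N\CCCCCCOc1cc2oc(=O)cc(C)c2cc1Cl`: 21800 nM
Compound 2 `Cc1nn(C)c(Oc2cccc(Br)c2)c1/C=N\CCCCCCOc1cc2oc(=O)cc(C)c2cc1Cl`: 3610 nM
Compound 3 `Cc1nn(C)c(Oc2ccc(I)cc2)c1/C=N\CCCCCCOc1cc2oc(=O)cc(C)c2cc1Cl`: 16800 nM

In a functional assay on U-87MG ATCC cells for antiproliferative activity against U-87 MG (Homo sapiens), read by MTT assay, with a stated time of 72 h (a higher number here means a weaker inhibitor, a lower number a stronger inhibitor), compound 3 gives 16800 nM, the second highest of the three numbers. The step of a 1.3-fold lower number from compound 1 to compound 3 (0.11 log units; within the scatter) lies within the scatter, so compound 1 and compound 3 cannot be told apart, whereas a 4.7-fold higher number from compound 2 to compound 3 (0.67 log units; beyond the scatter) lies beyond it. Compound 4 `Cc1ccc(Oc2c(/C=N\CCCCCCOc3cc4oc(=O)cc(C)c4cc3Cl)c(C)nn2C)cc1` differs from compound 3 by methyl in place of iodo on an aromatic carbon. The measured steps, a 6.0-fold lower number from compound 1 to compound 2 (0.78 log units; beyond the scatter) and a 4.7-fold higher number from compound 2 to compound 3 (0.67 log units; beyond the scatter), each move the halogen to another place on that ring; none swaps the group itself while keeping its place, so none bears directly on this change. With nothing pointing either way, compound 4 is expected to stay close to compound 3, the estimated step being a 1.1-fold higher number from compound 3 to compound 4 (0.03 log units; within the scatter), within the scatter. The estimate for compound 4 in this assay is 18000 nM, ranging from 6000 nM to 54000 nM.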

Compound 4, half-maximal inhibitory concentration: 23600 nM
Estimate against measurement, compound 4: 1.3-fold (0.12 log units) below, within the range that was stated.
By their numbers in this assay, from the lowest: compound 2; then compounds 3, 1 and 4 (each within the scatter of the next).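

Swapping the group while keeping its place, methyl in place of iodo on this aromatic carbon leaves this assay unable to separate the two compounds (a 1.4-fold higher number from compound 3 to compound 4 (0.15 log units; within the scatter)). Compound 4 also cannot be told apart from the 2-bromophenyl compound (a 1.1-fold higher number from compound 1 to compound 4 (0.03 log units; within the scatter)), while the 3-bromophenyl compound remains clearly separate (a 6.5-fold higher number from compound 2 to compound 4 (0.82 log units; beyond the scatter)). Nothing available explains these results.

Open, from the compounds shown here alone, is whether the stronger result seen with 3-bromophenyl depends on bromine itself. An amine or a carboxylic acid on this ring could test how far the number moves with a very different group.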